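Methyl in Place of Chloro: Expected Permeability of Compound 3

The compounds below may be only part of what the source reports. "The series", "measured", "known", "first", "only" and "open" are said of these compounds alone.

Compound 1 `CNC(=O)c1cc(C(=O)N[C@H]2CC[C@H](O)CC2)c([C@@H](C)c2ccc(Cl)cc2)o1` has been measured in an ADME assay for permeability (a higher number here means that the compound crosses the layer faster, a lower number that the compound crosses the layer more slowly), where compound 1 gives 150 nm/s. The only other measured compound, compound 2 `CNC(=O)c1cc(C(=O)N[C@H]2[C@@H]3COC[C@@H]32)cc2c1O[C@H](CF)[C@H]2c1ccccc1`, gives 165 nm/s in this assay; the two numbers lie within the scatter of each other, so compound 1 stands level with compound 2 on the evidence shown, and no order between them can be claimed. Compound 3 `CNC(=O)c1cc(C(=O)N[C@H]2CC[C@H](O)CC2)c([C@@H](C)c2ccc(C)cc2)o1` has not yet been measured in this assay. It differs from compound 1 in a single place: methyl in place of chloro on an aromatic carbon. Among the measured compounds shown here, no step between two measured compounds is available to show how this exchange moves the read-out, and compound 2 differs from compound 1 in more than one place, so only its value can be cited. With nothing pointing in either direction, the step from compound 1 to compound 3 is expected to be small and within the scatter, neither clearly up nor clearly down: no change at the digits printed from compound 1 to compound 3 (within the scatter). Compound 3 is therefore estimated to give 150 nm/s in this assay, with a range from 90 nm/s to 250 nm/s.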

Compound 3, apparent permeability: 108 nm/s
The estimate for compound 3 lay 1.4-fold (0.14 log units) above the measured number, and the stated range covers the measured number.
By their numbers in this assay, from the lowest: compounds 3, 1 and 2 (each within the scatter of the next).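

The first step read at this place, on an aromatic carbon of a six-membered aromatic ring of carbon only and para to a large group, is a 1.4-fold lower number from compound 1 to compound 3 (0.14 log units; within the scatter) in this assay. Compound 3 therefore stands level with compound 1 on this read-out, and methyl in place of chloro is not shown here to move the number beyond the scatter, which the earlier compounds could not show because no step linked them. The compounds shown hold no measurement that would account for this result, so it stands as an observation about this single pair.

Among the compounds shown here, what remains open is whether a group of another kind at this same place, such as an amine, a carboxylic acid or a longer chain, would give a step beyond the scatter, since chloro and methyl are the only two groups seen here. For the compounds shown here, it is also open whether methyl in place of chloro would read the same way on another core, since this exchange is seen only on the core of compound 1.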